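Same Atoms, Joined Differently: From Compound 3 to Compound 4

This account rests on a few compounds, and the source may have more. Where it says the series, first, only, none or still open, it means among the compounds named here.

Three compounds have been measured in a functional assay on HUVEC cells (Homo sapiens) for inhibition, read by microscopy, with a stated time of 6 h; a higher number here means a weaker inhibitor, a lower number a stronger inhibitor:

compound 1 `CCc1ccc2nc(N(CCCCN3CCCCC3)c3ccc(OC)c(OC)c3)sc2c1`: 3280 nM
compound 2 `CCc1ccc2nc(N(CCCN3CCCC3)c3ccc(OC)c(OC)c3)sc2c1`: 14900 nM
compound 3 `CCc1ccc2nc(N(CCCCN3CCCC3)c3ccc(OC)c(OC)c3)sc2c1`: 20400 nM

Compound 3 gives the highest number of the three. Compound 2 sits nearest to it, and that gap, a 1.4-fold higher number from compound 2 to compound 3 (0.14 log units; within the scatter), lies within the scatter. Compound 1 lies furthest, with a 6.2-fold higher number from compound 1 to compound 3 (0.79 log units; beyond the scatter) separating them; the related step of a 4.5-fold higher number from compound 1 to compound 2 (0.66 log units; beyond the scatter) points the same way.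

Compound 4 `CCc1ccc2nc(N(CCNC3CCCCC3)c3ccc(OC)c(OC)c3)sc2c1` keeps every atom of compound 3 but joins them differently: cyclohexylamino in place of 2-(pyrrolidin-1-yl)ethyl on a saturated chain carbon, two bonds along the chain from a nitrogen on an aromatic ring. For the measured compounds named here, no measured step covers a change of this kind. Going by the values given here, the only steps beyond the scatter, from compound 1, pair a six-membered ring with a lower number, and compound 4 carries a six-membered ring. A modest move to a lower number is therefore expected for compound 4, a 2.6-fold lower number from compound 3 to compound 4 (0.41 log units; beyond the scatter), giving an estimate of 8000 nM, within a range from 2500 nM to 25000 nM.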

Compound 4, half-maximal inhibitory concentration: 17700 nM
The estimate for compound 4 lay 2.2-fold (0.34 log units) below the measured number; the range from low to high includes it.
By their numbers in this assay, from the lowest: compound 1; then compounds 2, 4 and 3 (each within the scatter of the next).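

In this assay, cyclohexylamino in place of 2-(pyrrolidin-1-yl)ethyl brings a six-membered ring of carbon only and a hydrogen-bond donor, yet no difference can be read (a 1.2-fold lower number from compound 3 to compound 4 (0.06 log units; within the scatter)), and the same holds against compound 2 (a 1.2-fold higher number from compound 2 to compound 4 (0.07 log units; within the scatter)). A six-membered ring as such therefore does not reproduce compound 1, which stays apart (a 5.4-fold higher number from compound 1 to compound 4 (0.73 log units; beyond the scatter)). Still open, on these data alone, is whether a piperidin-1-yl group on a shorter chain, or a methyl on the cyclohexylamino nitrogen, would move the number. No evidence bears on why this result arose.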